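Compound 1 to compound 3: a change on sulfur

The source may hold more compounds than are shown below. What is called first, only, known or untested is meant among the compounds shown, and "the series" means these compounds.

For the measured compounds named here, in a toxicity assay on GES1 cells (Homo sapiens) for inhibition, read by MTT assay, with a stated time of 72 h (on this read-out lower numbers stand for stronger inhibition and higher numbers for weaker inhibition), compound 1 `Cc1cc(N2CC[C@@H](C)[C@@H](N(C)c3ncnc4[nH]ccc34)C2)n2nc(SCc3nc4ccccc4[nH]3)nc2n1` gives 40200 nM, the only exact number available so far. Compound 2 `CCCCCc1c(C)nc2nc(SCc3ccc(Cl)cc3)nn2c1N1CC[C@@H](C)[C@@H](N(C)c2ncnc3[nH]ccc23)C1` is recorded as > 100000 nM, which is a limit of the assay and not a number. Compound 3 `Cc1ccc(CSc2nc3nc(C)cc(N4CC[C@@H](C)[C@@H](N(C)c5ncnc6[nH]ccc56)C4)n3n2)cc1` has yet to be measured. Its structure departs from that of compound 1 in one place: 4-methylphenyl in place of 1H-benzimidazol-2-yl on a saturated chain carbon bound to a sulfur. Here, 4-methylphenyl stands in place of 1H-benzimidazol-2-yl on a saturated chain carbon bound to a sulfur. Going by the values given here, no measured pair of compounds shows what such a change does, so the expectation starts from compound 1 at 40200 nM. In this assay, a small step towards weaker inhibition is expected, a 1.4-fold higher number from compound 1 to compound 3 (0.14 log units; within the scatter), with little confidence in its direction. The estimate for compound 3 is 55000 nM, with an expected range from 20000 nM to 100000 nM.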

Compound 3, half-maximal inhibitory concentration: 82500 nM
Estimate against measurement, compound 3: 1.5-fold (0.18 log units) below; the measured number falls inside the stated range.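

In this assay, 4-methylphenyl in place of 1H-benzimidazol-2-yl on a saturated chain carbon bound to a sulfur gives a 2.1-fold higher number from compound 1 to compound 3 (0.31 log units; beyond the scatter), the first sign that the read-out responds to the group at this position. The change is modest, and it runs towards weaker inhibition as 1H-benzimidazol-2-yl, with its five-membered aromatic ring, its hydrogen-bond donor and its hydrogen-bond acceptor, gives way to a single six-membered aromatic ring of carbon only. Compound 2 is recorded only at a limit, which is not a number: the limit of > 100000 nM in this assay, at which 1 of the 3 values shown sits.

This one pair cannot show which part of the change matters, the loss of the five-membered ring, of the two nitrogens or the arrival of the methyl. On these data alone, how an unsubstituted phenyl, a 1H-imidazol-2-yl or a benzyl carrying an amine would read at this position stays open.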